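The source may hold more compounds than are shown below. What is called first, only, known or untested is meant among the compounds shown, and "the series" means these compounds.

Working notes on the series. Going by the values given here, compound 1 `CCCCc1ccc(-c2nc(C)c(/C(C)=N/NC(=N)N)s2)cc1` carries a butyl on an aromatic carbon of the shared core; in a physicochemical assay for solubility, read by spectrophotometry and turbidimetry, in phosphate buffer, with a stated time of 2 h (on this read-out lower numbers stand for lower solubility and higher numbers for higher solubility), compound 1 gives 65000 nM, the second highest of the three numbers so far. Compound 2 `C/C(=N\NC(=N)N)c1sc(-c2ccc(C#Cc3cccc(O)c3)cc2)nc1C` gives 55000 nM in this assay, and compound 3 `C/C(=N\NC(=N)N)c1sc(-c2ccc(C#Cc3ccc(N)cc3)cc2)nc1C` gives 105000 nM in this assay. The step of a 1.2-fold lower number from compound 1 to compound 2 (0.07 log units; within the scatter) and the step of a 1.6-fold higher number from compound 1 to compound 3 (0.21 log units; within the scatter) both exchange butyl for an arylethynyl group and neither leaves the scatter; the step of a 1.9-fold higher number from compound 2 to compound 3 (0.28 log units; within the scatter) between the two arylethynyl compounds also stays within the scatter.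

Compound 4 `C/C(=N\NC(=N)N)c1sc(-c2ccc(C#Cc3ccc(C)s3)cc2)nc1C` is not yet measured in this assay. It differs from compound 1 as follows: 2-(5-methylthiophen-2-yl)ethynyl in place of butyl on an aromatic carbon. The two measured steps that bear on this, from compound 1 to compound 2 and from compound 1 to compound 3, both swapped butyl for an arylethynyl group and both stayed within the scatter, so no step beyond the scatter is expected here either. The entering group carries no hydrogen-bond donor, unlike the groups entering in compound 2 and compound 3, so if anything the number is expected to sit at or a little under that of compound 1. Compound 4 is therefore estimated at 40000 nM in this assay, between 15000 nM and 110000 nM, a step of a 1.6-fold lower number from compound 1 to compound 4 (0.21 log units; within the scatter) expected to stay within the scatter.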

Compound 4, solubility: 12000 nM
Compound 4: the middle estimate sits 3.3-fold (0.52 log units) above what was measured; measured number outside the range, below it.
By their numbers in this assay, from the lowest: compound 4; then compounds 2, 1 and 3 (each within the scatter of the next).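

Working notes, continued. Going by these compounds alone, at this position, on an aromatic carbon para to a large group, exchanging butyl for an arylethynyl group does not always leave the number in this assay within the scatter: 2-(5-methylthiophen-2-yl)ethynyl in place of butyl gives a 5.4-fold lower number from compound 1 to compound 4 (0.73 log units; beyond the scatter), the first step beyond it. With the triple bond kept, the group on the triple-bonded carbon also separates the compounds, as 5-methylthiophen-2-yl in place of 4-aminophenyl gives an 8.8-fold lower number from compound 3 to compound 4 (0.94 log units; beyond the scatter) and 5-methylthiophen-2-yl in place of 3-hydroxyphenyl gives a 4.6-fold lower number from compound 2 to compound 4 (0.66 log units; beyond the scatter), so the arylethynyl unit alone does not fix the number. No measurement at hand bears on the origin of these steps.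

The compounds shown do not separate the contribution of the thiophene ring from that of its methyl, since neither an unsubstituted thiophen-2-yl nor a plain phenyl on the triple-bonded carbon is among them. As far as these compounds go, it also remains open whether an aminomethyl or a carboxylic acid in place of that methyl would return the number to the range of the other three compounds.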